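A Trifluoromethyl Step from Compound 1

This account rests on a few compounds, and the source may have more. Where it says the series, first, only, none or still open, it means among the compounds named here.

Among the compounds with values here, in a functional assay on MDA-MB-435 cells (Homo sapiens) for cytotoxicity, read by sulforhodamine B assay, with a stated time of 48 h (on this read-out lower numbers stand for stronger inhibition of growth and higher numbers for weaker inhibition of growth), compound 1 `Nc1c(C(=O)Nc2ccccc2)sc2nc3c(cc12)CCCCCC3` gives 52 nM, the lower of the two numbers measured so far, and compound 2 `Nc1c(C(=O)Nc2ccccc2Cl)sc2nc3c(cc12)CCCCCC3` gives 275 nM. Compound 3 `Nc1c(C(=O)Nc2cccc(C(F)(F)F)c2)sc2nc3c(cc12)CCCCCC3` is still unmeasured. It carries trifluoromethyl in place of hydrogen on an aromatic carbon, (trifluoromethyl in place of hydrogen on an aromatic carbon). Within the data shown here, the only measured step that bears on this puts chloro in place of hydrogen on an aromatic carbon, a 5.3-fold higher number from compound 1 to compound 2 (0.72 log units; beyond the scatter), a modest step beyond the scatter. Since that step concerns a different group, a similar or smaller rise is expected in this assay, with an expected change of a 2.5-fold higher number from compound 1 to compound 3 (0.40 log units; beyond the scatter). Compound 3 is estimated at 130 nM, within a range from 40 nM to 420 nM.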

Compound 3, concentration for 50% growth inhibition: 2100 nM
Beside the measured number, compound 3's estimate is 16-fold (1.21 log units) below it, and the stated range ends below it.
By their numbers in this assay, from the lowest: compound 1; then compound 2; then compound 3.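

In this assay, trifluoromethyl on an aromatic carbon meta to a large group gives a large step, a 40-fold higher number from compound 1 to compound 3 (1.61 log units; beyond the scatter), against the modest one for chloro, a 5.3-fold higher number from compound 1 to compound 2 (0.72 log units; beyond the scatter). Both groups on this six-membered aromatic ring raise the number, so among these three compounds the unsubstituted ring of compound 1 stays lowest. Nothing given here accounts for the size of this rise. From the compounds shown here alone, whether methyl, an amine or a carboxylic acid at the same place would keep the number close to that of compound 1 remains open, as does how trifluoromethyl would behave elsewhere on the ring.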